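The compounds below may be only part of what the source reports. "The series", "measured", "known", "first", "only" and "open" are said of these compounds alone.

Measured compounds:
compound 1 `CCCn1cnc2c(N)nc(NCCCc3ccccc3)nc21` gives 3640 nM;
compound 2 `CCCn1c(Br)nc2c(N)nc(NCCCc3ccccc3)nc21` gives 583 nM;
compound 3 `CCCn1cnc2c(NCc3ccccc3)ncnc21` gives 42800 nM.

All three were tested in an assay on CHO cells for displacement of a labelled ligand from adenosine receptor A1 (Homo sapiens); a higher number here means a weaker inhibitor, a lower number a stronger inhibitor. Compound 1 and compound 2 share one core; compound 2 carries a single alteration, (bromo in place of hydrogen on an aromatic carbon), and this brought a 6.2-fold lower number from compound 1 to compound 2 (0.80 log units; beyond the scatter). Compound 3 rests on a different core, and the difference between the two cores is not broken down here. What can be said is that compound 3 gives the highest of the three numbers, the nearest being compound 1.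

Compound 4 `CCCn1c(Br)nc2c(NCc3ccccc3)ncnc21` has not yet been measured. It stands to compound 3 as compound 2 stands to compound 1: the alteration is bromo in place of hydrogen on an aromatic carbon, the same change at the same place as before, and it occurs twice among these compounds. Among the compounds with values here, since that change produced a 6.2-fold lower number from compound 1 to compound 2 (0.80 log units; beyond the scatter), the expectation is that compound 4 will show a step of comparable size relative to compound 3, namely a 6.1-fold lower number from compound 3 to compound 4 (0.79 log units; beyond the scatter), although with only one earlier example the size of the step is uncertain. On that basis compound 4 is estimated to give 7000 nM in this assay, with a range from 2500 nM to 20000 nM.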

Compound 4, inhibition constant: 5620 nM
Beside the measured number, compound 4's estimate is 1.2-fold (0.10 log units) above it, within the range that was stated.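

In this assay, bromo in place of hydrogen on an aromatic carbon, on the carbon next to the ring atom that bears a propyl group, gave a 7.6-fold lower number from compound 3 to compound 4 (0.88 log units; beyond the scatter). Set beside the earlier step on the core of compound 1, this shows that the change carried over to the core of compound 3 at much the same size, so in this small set its effect on the number can be read as roughly independent of which of the two cores carries it: the same change on two cores in this assay, a 6.2-fold lower number (0.80 log units; beyond the scatter) from compound 1 to compound 2 and a 7.6-fold lower number (0.88 log units; beyond the scatter) from compound 3 to compound 4, 1.2-fold (0.09 log units) apart, within the scatter of two such steps
Within the data shown here, two cores are still only two examples, so this does not show that the step would hold on a third core, and it does not explain why bromo lowers the number in either case.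

The compounds shown leave open whether another group at this same place, such as chloro, iodo, methyl or an amine, would give a step of similar size, as only hydrogen and bromo appear there. They also leave open whether the bromo step would stay the same if a longer chain stood in place of the propyl group.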